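The source may hold more compounds than are shown below. What is called first, only, known or untested is meant among the compounds shown, and "the series" means these compounds.

In a functional assay on MCF7 cells (Homo sapiens) for cytotoxicity, read by CellTiter-Glo, with a stated time of 5 days (on this read-out lower numbers stand for stronger inhibition and higher numbers for weaker inhibition), compound 1 `CC/C(=C(/c1ccc(/C=C/C(=O)O)cc1)c1ccc2[nH]ncc2c1)c1ccccc1` gives 7.2 nM. Compound 2 `CC/C(=C(/c1ccc(/C=C/C(=O)O)cc1)c1ccc2[nH]nc(C)c2c1)c1ccccc1` returns only a limit of the assay, > 1000 nM. Compound 3 `CC/C(=C(/c1ccc(/C=C/C(=O)O)cc1)c1ccc2[nH]ncc2c1C)c1ccccc1` gives 50 nM, the higher of the two actual numbers in this assay, and compound 1 holds the nearest value to it.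

Compound 4 `CC/C(=C(/c1ccc(/C=C/C(=O)O)cc1)c1ccc2[nH]ncc2c1F)c1ccccc1` has fluoro in place of methyl on an aromatic carbon of compound 3, ortho to a large group: fluoro in place of methyl on an aromatic carbon. Cut one bond further out, the change reads 4-methyl-1H-indazol-5-yl to 4-fluoro-1H-indazol-5-yl.

The step that bears most directly on this carbon is methyl in place of hydrogen, which gave a 6.9-fold higher number from compound 1 to compound 3 (0.84 log units; beyond the scatter). Methyl on a different aromatic carbon gave an at least 130-fold higher number from compound 1 to compound 2 (2.14 log units; beyond the scatter), a large step. The comparison of those two methyl placements, an at least 20-fold lower number from compound 2 to compound 3 (1.30 log units; beyond the scatter), says less about the present exchange. Going by the values given here, removing the methyl should undo part of the modest rise seen at this carbon, although no measured compound here carries fluoro to show how much. The estimate is a 3.1-fold lower number from compound 3 to compound 4 (0.49 log units; beyond the scatter), a modest move to a lower number. Compound 4 is expected at 16 nM, with an estimated range of 5 nM to 70 nM.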

Compound 4, half-maximal inhibitory concentration: 3 nM
Compound 4: middle estimate off by 5.3-fold (0.73 log units), on the high side; the measured number lies below the stated range.
By their numbers in this assay, from the lowest: compound 4; then compound 1; then compound 3. At a limit, above all of these: compound 2.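

In this assay, the carbon that carries the methyl of compound 3 proves able to take a substituent with a gain rather than a loss: a 2.4-fold lower number from compound 1 to compound 4 (0.38 log units; beyond the scatter), with fluoro in place of hydrogen, so the direction is opposite to the rise seen with methyl at this carbon. The exchange of methyl for fluoro therefore does more than undo the methyl, since it goes beyond the hydrogen value, and its full size is large: a 17-fold lower number from compound 3 to compound 4 (1.22 log units; beyond the scatter). Set against the 3-methyl-1H-indazol-5-yl group, the 4-fluoro-1H-indazol-5-yl group gives an at least 330-fold lower number from compound 2 to compound 4 (2.52 log units; beyond the scatter), but this step starts from a limit and fixes only a minimum size: the limit of > 1000 nM in this assay, at which 1 of the 4 values shown sits.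

On these data alone, with only hydrogen, methyl and fluoro seen at this carbon, it remains open whether the lower number is particular to fluoro or would also hold for chloro, hydroxyl or methoxy. As far as these compounds go, it also remains open whether fluoro on the aromatic carbon that carries the methyl of compound 2 would be tolerated there, as no fluoro or hydrogen comparison beyond the parent exists for that carbon.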